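This account rests on a few compounds, and the source may have more. Where it says the series, first, only, none or still open, it means among the compounds named here.

Going by the values given here, in a functional assay on DU-145 cells (Homo sapiens) for cytotoxicity, read by CCK-8 assay, with a stated time of 4 days (a higher number here means a weaker inhibitor, a lower number a stronger inhibitor), compound 1 `Oc1ccc(-c2cc(-c3ccccc3O)cc(-c3cccc(O)c3)n2)cc1` gives 5370 nM, the only exact number so far. Compound 2 `Oc1cccc(-c2cc(-c3ccccc3O)cc(-c3cccc(O)c3)n2)c1` gives > 50000 nM, which is a limit of the assay and not a number. The swap of 3-hydroxyphenyl in place of 4-hydroxyphenyl shows an at least 9.3-fold higher number from compound 1 to compound 2 (0.96 log units; beyond the scatter), a step beyond the scatter. Compound 3 `Oc1ccc(-c2cc(-c3ccccc3O)cc(-c3ccc(O)cc3)n2)cc1` has not been measured yet. It makes the opposite swap at the other flank of the core: 4-hydroxyphenyl in place of 3-hydroxyphenyl, next to the ring nitrogen, (4-hydroxyphenyl in place of 3-hydroxyphenyl on an aromatic carbon). Among the compounds with values here, only one measured step bears on this change, namely an at least 9.3-fold higher number from compound 1 to compound 2 (0.96 log units; beyond the scatter), and it ran the opposite way. A modest move to a lower number in this assay is therefore expected, though one step is thin ground and the result could also stay within the scatter. The expected change is a 2.1-fold lower number from compound 1 to compound 3 (0.33 log units; beyond the scatter). For compound 3 the estimated value is 2500 nM, with an expected range of 600 nM to 10000 nM.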

Compound 3, half-maximal inhibitory concentration: 980 nM
Beside the measured number, compound 3's estimate is 2.6-fold (0.41 log units) above it; the range from low to high includes it.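

With the same atoms joined differently, placing a 4-hydroxyphenyl group instead of a 3-hydroxyphenyl group next to the ring nitrogen gives a 5.5-fold lower number from compound 1 to compound 3 (0.74 log units; beyond the scatter) in this assay. The 4-hydroxyphenyl group therefore goes with the lower number at this flank as well as at the other flank of the shared core, and none of the compounds shown goes against this. As far as these compounds go, the earlier step remains open-ended, as compound 2 gives a limit and not a number: the limit of > 50000 nM in this assay, at which 1 of the 3 values shown sits.

All of the compounds shown keep the 2-hydroxyphenyl group and carry a hydroxyl on each flanking ring, so it remains open whether an amine or a carboxylic acid in place of the hydroxyl at this position would keep the lower number. Why the place of the hydroxyl matters also remains open.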